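Ethyl versus methyl on the aminoquinazoline chain

This account rests on a few compounds, and the source may have more. Where it says the series, first, only, none or still open, it means among the compounds named here.

Measured compounds:
Compound 1 `CCNc1nc(NCc2ccc(NC(=O)c3ccc(F)cc3)cc2)c2ccccc2n1`: 2300 nM
Compound 2 `CNc1nc(NCc2ccc(C(=O)Nc3ccc(F)cc3)cc2)c2ccccc2n1`: 4100 nM
Compound 3 `CNc1nc(NCc2ccc(NC(=O)c3ccc(F)cc3)cc2)c2ccccc2n1`: 2000 nM

In a functional assay on SW480 cells (Homo sapiens) for inhibition, read by luminescence and resazurin assay, with a stated time of 3 days (a lower number here means a stronger inhibitor, a higher number a weaker inhibitor), compound 2 gives the highest number of the three; compound 1 lies within the scatter of it, while the step of a 2.1-fold lower number from compound 2 to compound 3 (0.31 log units; beyond the scatter) is modest but beyond the scatter. Compound 4 `CCNc1nc(NCc2ccc(C(=O)Nc3ccc(F)cc3)cc2)c2ccccc2n1` differs from compound 2 by one change: methyl in place of hydrogen on a saturated chain carbon bound to a nitrogen on an aromatic ring. The same change, run backwards, is the step of a 1.2-fold lower number from compound 1 to compound 3 (0.06 log units; within the scatter), which stayed within the scatter. Among the compounds with values here, only that one comparison bears on the question, so no shift beyond the scatter is expected in this assay. The change is expected to amount to a 1.1-fold higher number from compound 2 to compound 4 (0.06 log units; within the scatter). Compound 4 is therefore estimated at 4700 nM, with a range from 2300 nM to 9500 nM.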

Compound 4, half-maximal inhibitory concentration: 2500 nM
Beside the measured number, compound 4's estimate is 1.9-fold (0.27 log units) above it, within the range that was stated.
By their numbers in this assay, from the lowest: compounds 3, 1, 4 and 2 (each within the scatter of the next, the first and the last beyond it).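

With the (4-fluorophenyl)carbamoyl group in place, in this assay, the change from methylamino to ethylamino gives a 1.6-fold lower number from compound 2 to compound 4 (0.21 log units; within the scatter), so this change now stays within the scatter on both cores: the same change on two cores in this assay, a 1.2-fold lower number (0.06 log units; within the scatter) from compound 1 to compound 3 and a 1.6-fold higher number (0.21 log units; within the scatter) from compound 4 to compound 2, 1.9-fold (0.28 log units) apart, within the scatter of two such steps. With ethylamino on the chain, placing (4-fluorophenyl)carbamoyl where ((4-fluorophenyl)carbonyl)amino stood gives a 1.1-fold higher number from compound 1 to compound 4 (0.04 log units; within the scatter), so the modest step seen with methylamino does not recur, although the two steps agree within the scatter: the same change on two cores in this assay, a 2.1-fold lower number (0.31 log units; beyond the scatter) from compound 2 to compound 3 and a 1.1-fold lower number (0.04 log units; within the scatter) from compound 4 to compound 1, 1.9-fold (0.28 log units) apart, within the scatter of two such steps. From the compounds shown here alone, whether a longer chain such as propyl, or a plain amino group in place of methylamino, would move the number beyond the scatter stays open.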